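Exchanging the oxolan-2-yl group of compound 2

The source may hold more compounds than are shown below. What is called first, only, known or untested is meant among the compounds shown, and "the series" means these compounds.

For the measured compounds named here, in a functional assay on SH-SY5Y cells (Homo sapiens) for cytotoxicity, read by MTT assay, with a stated time of 72 h (a higher number here means a weaker inhibitor, a lower number a stronger inhibitor), compound 2 `O=C1c2c[n+]([O-])c3ccccc3c2C(=O)c2c1c1ccccc1n2Cc1cn([C@H]2C[C@H](O)[C@@H](CO)O2)nn1` gives 620 nM, the only actual number so far. Compound 1 `CC1(C)OC[C@@H](Cn2cc(Cn3c4c(c5ccccc53)C(=O)c3c[n+]([O-])c5ccccc5c3C4=O)nn2)O1` gives > 1000 nM, which is a limit of the assay and not a number. Going by the values given here, the one measured step is an at least 1.6-fold lower number from compound 1 to compound 2 (0.20 log units; that floor lies within the scatter), and it brings in 4-hydroxy-5-(hydroxymethyl)oxolan-2-yl in place of (2,2-dimethyl-1,3-dioxolan-4-yl)methyl on an aromatic nitrogen.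

Compound 3 `O=C1c2c[n+]([O-])c3ccccc3c2C(=O)c2c1c1ccccc1n2Cc1cn([C@@H]2O[C@H](CO)[C@@H](O)[C@H](O)[C@H]2O)nn1` keeps the shared core of compound 2 and changes that same group: 3,4,5-trihydroxy-6-(hydroxymethyl)oxan-2-yl in place of 4-hydroxy-5-(hydroxymethyl)oxolan-2-yl on an aromatic nitrogen. In words, 3,4,5-trihydroxy-6-(hydroxymethyl)oxan-2-yl stands in place of 4-hydroxy-5-(hydroxymethyl)oxolan-2-yl on an aromatic nitrogen. Among the compounds with values here, no measured step covers this exchange directly. The nearest guide is an at least 1.6-fold lower number from compound 1 to compound 2 (0.20 log units; that floor lies within the scatter), which touches the same place but does not establish a change beyond the scatter. No step beyond the scatter is therefore expected in this assay, and no direction is firmly expected. The expected step is a 1.1-fold higher number from compound 2 to compound 3 (0.05 log units; within the scatter). Compound 3 is estimated at 700 nM, with an expected range from 300 nM to 1600 nM.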

Compound 3, half-maximal inhibitory concentration: 880 nM
Estimate against measurement, compound 3: 1.3-fold (0.10 log units) below; low and high end bracket the measured number.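

In this assay, the exchange of 4-hydroxy-5-(hydroxymethyl)oxolan-2-yl, with 8 heavy atoms and 2 hydrogen-bond donors, for 3,4,5-trihydroxy-6-(hydroxymethyl)oxan-2-yl, with 11 heavy atoms and 4 hydrogen-bond donors, gives a 1.4-fold higher number from compound 2 to compound 3 (0.15 log units; within the scatter), so this exchange on the aromatic nitrogen does not separate the two compounds. Measured against the dioxolane-bearing compound, the new group gives only a floor, an at least 1.1-fold lower number from compound 1 to compound 3 (0.05 log units; that floor lies within the scatter), so no difference beyond the scatter is established for this exchange either. Compound 1 gives > 1000 nM, which is a limit of the assay and not a number, so the size of both steps from it remains unknown: the limit of > 1000 nM in this assay, at which 1 of the 3 values shown sits.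

Going by these compounds, whether a group of another kind on this aromatic nitrogen, such as a primary amine, a carboxylic acid or a plain butyl chain, would give a step beyond the scatter in this assay remains open. On these data alone, all three compounds also share one core, so the effect of any change elsewhere on the molecule remains open too.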